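Moving the fluorine from compound 2 to compound 3

A few compounds are considered here, and "the series" means these few. Any claim that something is new, unique, unknown or untested is made for them only; others in the source may bear on it.

Measured in a functional assay on MIA PaCa-2 cells (Homo sapiens) for inhibition, read by MTT assay, with a stated time of 48 h; a higher number here means a weaker inhibitor of growth, a lower number a stronger inhibitor of growth:
Compound 1 `CN1CC[C@H](c2c(O)cc(O)c3c(=O)cc(/C=C/c4cccc(Cl)c4)oc23)[C@H](O)C1`: 10000 nM
Compound 2 `CN1CC[C@H](c2c(O)cc(O)c3c(=O)cc(/C=C/c4cccc(F)c4)oc23)[C@H](O)C1`: 2000 nM

Of these two compounds, compound 2 has the lower number, at 2000 nM, and compound 1 gives 10000 nM. Compound 3 `CN1CC[C@H](c2c(O)cc(O)c3c(=O)cc(/C=C/c4ccccc4F)oc23)[C@H](O)C1` has not yet been measured. It differs from compound 2 by 2-fluorophenyl in place of 3-fluorophenyl on a double-bonded chain carbon bound to a double-bonded chain carbon, with 2-fluorophenyl in place of 3-fluorophenyl on a double-bonded chain carbon bound to a double-bonded chain carbon. Among the measured compounds shown here, only one measured step bears on this change: a 5.0-fold lower number from compound 1 to compound 2 (0.70 log units; beyond the scatter). That step swapped chloro for fluoro on an aromatic carbon and moved no group, so the data show no direction for the new change. A smaller step than that one is expected in this assay, possibly none beyond the scatter. The estimated step is a 1.5-fold higher number from compound 2 to compound 3 (0.18 log units; within the scatter). Compound 3 is expected at 3000 nM, with an estimated range from 900 nM to 10000 nM.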

Compound 3, concentration for 50% growth inhibition: 3000 nM
Compound 3: the middle estimate sits on the measured number at the digits printed; the measured number falls inside the stated range.
By their numbers in this assay, from the lowest: compounds 2 and 3 (each within the scatter of the next); then compound 1.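

In this assay the fluorine can sit in either placement shown without a change that stands out from the scatter: 2-fluorophenyl in place of 3-fluorophenyl gives (a 1.5-fold higher number from compound 2 to compound 3 (0.18 log units; within the scatter)). Compound 3 also keeps a distance from the chloro compound, with 2-fluorophenyl in place of 3-chlorophenyl giving (a 3.3-fold lower number from compound 1 to compound 3 (0.52 log units; beyond the scatter)), so both fluoro compounds shown have lower numbers than compound 1, and none of the three goes against this. No measurement shown here bears on why the two fluoro compounds read alike or why the chloro compound differs from them.

The compounds shown leave open whether any halogen is needed, as a plain phenyl would test. They also leave open how a 2-chlorophenyl, or a phenyl carrying a methoxy group or an amine, would read in this position.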